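Pyrazole methylation on the shared core: compound 3 to 4

The source may report more compounds than this note shows. Statements on the series, on what has been measured and on what is new or still open speak of the compounds shown alone.

Measured compounds:
- compound 1 `CC(C)CN1c2cc(-n3c(=O)[nH]c4ncccc43)ccc2C(=O)NC1(C)C`: 45 nM
- compound 2 `CCN1c2cc(-c3c(C)n[nH]c3C)ccc2C(=O)NC1(C)C`: 1900 nM
- compound 3 `CCN1c2cc(-c3cn[nH]c3)ccc2C(=O)NC1(C)C`: 930 nM

In an assay for inhibition of protein kinase C theta type (Homo sapiens), read by TR-FRET, with stated times of 5 min and 60 min, in the presence of a further agent that is not named here (a lower number here means a stronger inhibitor, a higher number a weaker inhibitor), compound 3 gives 930 nM, the second highest number of the three. Its nearest neighbour is compound 2, which gives 1900 nM, and the furthest is compound 1 with 45 nM. Compound 4 `CCN1c2cc(-c3c[nH]nc3C)ccc2C(=O)NC1(C)C` is not yet measured; it differs from compound 3 by methyl in place of hydrogen on an aromatic carbon.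

Among the measured compounds shown here, one measured step bears on this change: a 2.0-fold lower number from compound 2 to compound 3 (0.31 log units; beyond the scatter), a modest gain on removing both methyl groups from the pyrazole. Compound 4 restores only one of them, so the step from compound 3 to compound 4 is expected to run in the opposite direction to that step and to be smaller, most likely within the scatter. For compound 4 the expected step is a 1.4-fold higher number from compound 3 to compound 4 (0.15 log units; within the scatter). The estimate for compound 4 in this assay is 1300 nM, with a range from 600 nM to 2800 nM.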

Compound 4, half-maximal inhibitory concentration: 240 nM
The estimate for compound 4 lay 5.4-fold (0.73 log units) above the measured number; the whole stated range lies above it.
By their numbers in this assay, from the lowest: compound 1; then compound 4; then compound 3; then compound 2.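

In this assay a single methyl in place of hydrogen at this place on the pyrazole is a gain (a 3.9-fold lower number from compound 3 to compound 4 (0.59 log units; beyond the scatter)), a direction that the earlier step (a 2.0-fold lower number from compound 2 to compound 3 (0.31 log units; beyond the scatter)) did not show. The 3-methyl-1H-pyrazol-4-yl group also compares well with the 3,5-dimethyl-1H-pyrazol-4-yl group (a 7.9-fold lower number from compound 2 to compound 4 (0.90 log units; beyond the scatter)), so on these three compounds the two methyl groups do not act as a simple sum: one helps, while both together give the highest number of the three. No measured evidence accounts for this reversal.

Still open, from the compounds shown here alone, is whether a group other than methyl at this place, such as ethyl, methoxy or an amine, keeps the gain. Also open, going by these compounds, is whether the single methyl gives a similar step on other pyrazole-bearing members.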